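The source may hold more compounds than are shown below. What is called first, only, known or untested is meant among the compounds shown, and "the series" means these compounds.

Measured compounds in an assay on microsomes from liver for inhibition of acyl-CoA desaturase 1 (Rattus norvegicus); on this read-out lower numbers stand for stronger inhibition and higher numbers for weaker inhibition:
compound 1 `Cc1ccc(OC2CCN(c3ccc(-n4ccnc4)nn3)CC2)cc1` — 527 nM
compound 2 `OCc1nnc(-c2ccc(N3CCC(Oc4ccccc4C(F)(F)F)CC3)nn2)s1` — 3.2 nM
compound 3 `N#Cc1ccccc1OC1CCN(c2ccc(-n3ccnc3)nn2)CC1` — 236 nM

Among these three, compound 1 gives the highest number in this assay; compound 3 comes nearest, and compound 2 stands furthest off with a far lower number. Among the compounds with values here, compound 2 differs from compound 1 in more than one place, so its value shows only that the series reaches much lower numbers in this assay than compound 1 does; no single step can be drawn from that pair.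

The unmeasured compound 4 `CC(=O)c1ccccc1OC1CCN(c2ccc(-n3ccnc3)nn2)CC1` differs from compound 1 in one place: 2-acetylphenyl in place of 4-methylphenyl on an oxygen on a saturated carbon. Within the data shown here, the one measured step that bears on this change is a 2.2-fold lower number from compound 1 to compound 3 (0.35 log units; beyond the scatter), which likewise replaces the 4-methylphenyl with a phenyl carrying a single substituent, there a nitrile, here an acetyl group. Among the measured compounds shown here, with only this one comparison to draw on, a step of similar size and direction is expected for compound 4: a 2.0-fold lower number from compound 1 to compound 4 (0.31 log units; beyond the scatter), a modest lowering rather than a large one, since nothing measured here points to the acetyl group doing more than the nitrile did. For compound 4 the estimate in this assay is 260 nM, with a range from 100 nM to 650 nM.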

Compound 4, half-maximal inhibitory concentration: 34 nM
The estimate for compound 4 lay 7.6-fold (0.88 log units) above the measured number, and the stated range ends above it.
By their numbers in this assay, from the lowest: compound 2; then compound 4; then compound 3; then compound 1.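

In this assay, within the data shown here, the 2-acetylphenyl on the oxygen gives a 16-fold lower number from compound 1 to compound 4 (1.19 log units; beyond the scatter), a large step where the 2-cyanophenyl had given only the modest 2.2-fold lower number from compound 1 to compound 3 (0.35 log units; beyond the scatter), so this position can move the number much further than the earlier compounds showed. Exchanging the nitrile for acetyl on the aromatic carbon gives a 6.9-fold lower number from compound 3 to compound 4 (0.84 log units; beyond the scatter), which shows that the identity of this one substituent matters and that replacing 4-methylphenyl with a singly substituted phenyl does not by itself set the size of the step. Nothing on hand accounts for the difference between the acetyl and nitrile groups.

Both steps from compound 1 remove the 4-methylphenyl and bring in a group named at the 2-position, so the shift in where the substituent sits and the change in what it is cannot be separated. On these data alone, it also remains open whether the low number stays with the acetyl group alone or extends to a propanoyl group, a methyl ester, a primary amide or a 1-hydroxyethyl group at the same place.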